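A few compounds are considered here, and "the series" means these few. Any claim that something is new, unique, unknown or untested is made for them only; others in the source may bear on it.

Measured so far in a functional assay on HTB-54 cells (Homo sapiens) for cytotoxicity, read by MTT assay, with a stated time of 72 h; on this read-out higher numbers stand for weaker inhibition of growth and lower numbers for stronger inhibition of growth:
Compound 1 `CCCCC[Se]c1nc(NCc2ccc(SC)cc2)c2ccccc2n1`: 81300 nM.
Compound 2 `CSc1nc(NCc2ccc([Se]C)cc2)c2ccccc2n1`: > 100000 nM, a limit of the assay.
Compound 3 `COc1ccc(CNc2nc(SC)nc3ccccc23)cc1`: > 100000 nM, a limit of the assay.

Compound 3 thus stands at the limit, with no number known for it. Among the measured compounds shown here, compound 1 gives the only number of the three; the other two sit at the limit, as summed up in the limit of > 100000 nM in this assay, at which 2 of the 3 values shown sit. Compound 4 `CSc1ccc(CNc2nc(SC)nc3ccccc23)cc1` differs from compound 3 by methylsulfanyl in place of methoxy on an aromatic carbon. For the measured compounds named here, the one measured step on the same aromatic carbon, a step that the two limits leave unreadable from compound 2 to compound 3, cannot be read. The step from compound 3 to compound 4 therefore has no readable precedent, and no size or direction beyond the scatter can be derived from the numbers shown. Compound 4 is expected to remain near the limit, estimated at 120000 nM (range 50000 nM to 300000 nM). The expected step is a step that the limit leaves unreadable from compound 3 to compound 4.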

Compound 4, concentration for total growth inhibition: 44500 nM
For compound 4 the middle estimate is 2.7-fold (0.43 log units) above the measured one; the whole stated range lies above it.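

In this assay, among the compounds shown here, methylsulfanyl in place of methoxy on this aromatic carbon, para to a large group, gives the first readable change at this position: an at least 2.2-fold lower number from compound 3 to compound 4 (0.35 log units; beyond the scatter) with a limit on one side, and sulfur in place of selenium on the same carbon gives an at least 2.2-fold lower number from compound 2 to compound 4 (0.35 log units; beyond the scatter) on the same terms. Both steps are bounds, not sizes: the limit of > 100000 nM in this assay, at which 2 of the 4 values shown sit. Replacing the larger selenium group of compound 1 with the small sulfur group elsewhere gives a 1.8-fold lower number from compound 1 to compound 4 (0.26 log units; within the scatter) and so shows no readable change.

As far as these compounds go, the true size of both bounded steps stays open. Also open, from the compounds shown here alone, is whether an amine or a longer sulfur-linked chain on this carbon would carry the change further.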